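The compounds below may be only part of what the source reports. "The series", "measured", "known", "first", "only" and "open" are said of these compounds alone.

The measured compounds stand as follows. Compound 1 `Cc1cc(C)c(S(=O)(=O)N2CCC(N3CCC(O)CC3)CC2)c(C)c1` gives in an ADME assay on HCT-116 cells (Homo sapiens) for cytotoxicity, read by CellTiter-Glo, with a stated time of 72 h (a higher number here means a weaker inhibitor, a lower number a stronger inhibitor), only a limit, > 5000 nM. Compound 2 `Cc1cc(C)c(S(=O)(=O)N2CCC(N3CCC(C)CC3)CC2)c(C)c1` gives in this assay likewise a limit, > 5000 nM. Compound 3 `Cc1cc(C)c(S(=O)(=O)N2CCC(N3CCCCCC3)CC2)c(C)c1` gives in this assay again a limit, > 5000 nM.

Compound 2 therefore stands where every value shown stands: at a limit, not a number, and the evidence is summed up in the limit of > 5000 nM in this assay, at which 3 of the 3 values shown sit. The three steps among the measured compounds, a step that the two limits leave unreadable from compound 1 to compound 2, a step that the two limits leave unreadable from compound 1 to compound 3 and a step that the two limits leave unreadable from compound 2 to compound 3, are each unreadable in size for the same reason, since both ends sit at the limit.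

The unmeasured compound 4 `Cc1cc(C)c(S(=O)(=O)N2CCC(N3CCC(Cc4ccccc4)CC3)CC2)c(C)c1` differs from compound 2 by phenyl in place of hydrogen on a saturated chain carbon bound to a saturated ring carbon. Among the measured compounds shown here, none of the measured steps touches this kind of change, and none gives a readable size, so nothing here points toward a step in either direction beyond the scatter. The expectation for compound 4 is therefore that it stays near where compound 2 stands, with an expected step that the limit leaves unreadable from compound 2 to compound 4. Compound 4 is thus estimated at 8000 nM, within 2500 nM to 30000 nM, most likely reported once more as a limit.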

Compound 4, half-maximal inhibitory concentration: > 5000 nM
Compound 4 gave a limit, no number; the forecaster's own chance of this, stated with the estimate: 70%; the middle value lies beyond the limit too.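

Compound 4 gives > 5000 nM in this assay as well, a limit and not a number. Its steps from compound 1 and from compound 2 cannot be read in size, and the values all stand together: the limit of > 5000 nM in this assay, at which 4 of the 4 values shown sit. The compounds shown leave open how these four compare with one another in this assay and what change to the shared core would give a readable number.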